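This account rests on a few compounds, and the source may have more. Where it says the series, first, only, none or still open, it means among the compounds named here.

Compound 1 `CCN(CC)CN1C(=O)/C(=N\c2nc3ccc(C)cc3s2)c2ccccc21` and compound 2 `CCN(CC)CN1C(=O)/C(=N\c2nc3ccc(C)cc3s2)c2c(Br)cccc21` are built on one core, while compound 3 `O=C1C(=O)N(CN(c2ccccc2)c2ccccc2)c2ccccc21` and compound 4 `O=C1C(=O)N(CN(c2ccccc2)c2ccccc2)c2cccc(Br)c21` are built on another; the difference between the two cores is not broken down here. In a functional assay on MCF7 cells (Homo sapiens) for cytotoxicity, read by sulforhodamine B assay, with a stated time of 48 h (a lower number here means a stronger inhibitor of growth, a higher number a weaker inhibitor of growth), compound 1 gives 74800 nM, and compound 2 gives 30200 nM, so the change bromo in place of hydrogen on an aromatic carbon brought a 2.5-fold lower number from compound 1 to compound 2 (0.39 log units; beyond the scatter). Compound 3 gives 23700 nM in this assay. Compound 4 carries the same change, (bromo in place of hydrogen on an aromatic carbon), made on the other core, and its result is not yet known. Because the earlier step of a 2.5-fold lower number from compound 1 to compound 2 (0.39 log units; beyond the scatter) was modest, a step of similar size is expected here, namely a 2.2-fold lower number from compound 3 to compound 4 (0.33 log units; beyond the scatter). Compound 4 is therefore estimated at 11000 nM in this assay, with the expected range running from 4000 nM to 30000 nM.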

Compound 4, concentration for 50% growth inhibition: 110000 nM
Estimate against measurement, compound 4: 10-fold (1.00 log units) below; the measured number lies above the stated range.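

The bromo group did not carry over from one core to the other in this assay: on the core of compound 3, the change gave a 4.6-fold higher number from compound 3 to compound 4 (0.67 log units; beyond the scatter), a weaker result rather than the stronger one seen on the core of compound 1. Set side by side, the two steps run in opposite directions: the same change on two cores in this assay, a 2.5-fold lower number (0.39 log units; beyond the scatter) from compound 1 to compound 2 and a 4.6-fold higher number (0.67 log units; beyond the scatter) from compound 3 to compound 4, 11-fold (1.06 log units) apart, beyond the scatter of two such steps So in this series, the step on one core gave no safe guide to the step on the other, but with only one pair on each core, this does not show why the two differ.

From the compounds shown here alone, it remains open whether a chloro, fluoro or methoxy group on the same aromatic carbon would split the two cores in the same way. Going by these compounds, it also remains open whether a bromo group on a different aromatic carbon would do so.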